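Phenyl in Place of Isopentyl on the Shared Core

A few compounds are considered here, and "the series" means these few. Any claim that something is new, unique, unknown or untested is made for them only; others in the source may bear on it.

Compound 1, `COc1cccc(CNCCCNc2ccnc3cc(-c4ccc(F)cc4)ccc23)c1O`, gives in a physicochemical assay for acid dissociation, a value of 9.47.
Compound 2, `COc1cccc(CNCCCNc2ccnc3cc(CCC(C)C)ccc23)c1O`, gives in this assay a value of 9.47.
Compound 3, `COc1ccc(F)cc1CNCCCNc1ccnc2cc(CCC(C)C)ccc12`, gives in this assay a value of 9.47.

Compound 2 stands level with compound 1 and compound 3 at the digits shown. The step of no change at the digits printed from compound 1 to compound 2 (within the scatter) swapped the aryl group on the core for a chain, and the step of no change at the digits printed from compound 2 to compound 3 (within the scatter) altered the substituted benzyl group on the amine, and neither moved the read-out beyond the scatter.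

Compound 4 is `COc1cccc(CNCCCNc2ccnc3cc(-c4ccccc4)ccc23)c1O`. The change from compound 2 is phenyl in place of isopentyl on an aromatic carbon. The step that bears on it most directly is no change at the digits printed from compound 1 to compound 2 (within the scatter), since it too exchanged the group at this same position between an aryl ring and isopentyl, and it was flat. The account therefore expects no step beyond the scatter in this assay, that is, no change at the digits printed from compound 2 to compound 4 (within the scatter). For compound 4 the value in this assay is estimated at 9.47, with a range from 9.15 to 9.8.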

Compound 4, acid dissociation constant: 9.47
Estimate against measurement, compound 4: no gap at the digits printed, and the stated range covers the measured number.
By their numbers in this assay, from the lowest: compounds 1, 2, 3 and 4 (each within the scatter of the next).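

In this assay, an unsubstituted phenyl at this aromatic carbon reads like isopentyl, with no change at the digits printed from compound 2 to compound 4 (within the scatter), so the flat result seen earlier with 4-fluorophenyl does not depend on the fluoro group. Removing that fluoro group from the ring is itself flat, with no change at the digits printed from compound 1 to compound 4 (within the scatter), so both the exchange of ring for chain and the change on the ring leave the read-out where it was across these compounds. Nothing shown here offers an explanation for this flatness.

Among these compounds, the groups compared at this position hold only carbon, apart from the single fluoro group on the ring. Going by these compounds, whether an amine or a carboxylic acid, either on that ring or directly on the aromatic carbon, would produce a step beyond the scatter remains open.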